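Stability notes: carboxyphenyl in place of chlorophenyl on the shared core

The source may hold more compounds than are shown below. What is called first, only, known or untested is meant among the compounds shown, and "the series" means these compounds.

Measured so far:
compound 1 `CCCCCCCCc1ccc(OCC(=O)Cn2nnc(-c3cccnc3)n2)cc1`: 12%
compound 2 `CCCCCCCCc1ccc(OCC(=O)Cn2nnnc2-c2cccc(Cl)c2)cc1`: 41%

In an ADME assay on S9 fraction from liver (Rattus norvegicus) for metabolic stability, read by LC-MS, using NADPH, with a stated time of 30 min (a lower number here means that less of the compound is left, a higher number that more of the compound is left), compound 2 stands highest of the two numbers; the nearest, compound 1, lies a number lower that is beyond the scatter. For the measured compounds named here, the two measured compounds differ in more than one place, so no single step is known. Compound 3 `CCCCCCCCc1ccc(OCC(=O)Cn2nnnc2-c2ccc(C(=O)O)cc2)cc1` differs from compound 2 by 4-carboxyphenyl in place of 3-chlorophenyl on an aromatic carbon. Nothing measured tracks this change, so a step of modest size in either direction, possibly none beyond the scatter, is expected. Compound 3 is expected to give 45% (range 20% to 75%), meaning an estimated step of a number 4 percentage points higher from compound 2 to compound 3 (within the scatter).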

Compound 3, percent of the compound remaining: 6%
Beside the measured number, compound 3's estimate is 39 percentage points above it; measured number outside the range, below it.
By their numbers in this assay, from the lowest: compounds 3 and 1 (each within the scatter of the next); then compound 2.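

Setting 4-carboxyphenyl in place of 3-chlorophenyl on the shared core gives a number 35 percentage points lower from compound 2 to compound 3 (beyond the scatter) in this assay and is the first single change read in this series. This group on the aromatic carbon therefore has a large bearing on the percent remaining. The swap changes the ring substituent and where it sits together, and no available measurement bears on the reason for the step. Open, from the compounds shown here alone, is whether a plain phenyl, or a methyl ester or amide in place of the carboxylic acid, would stay near compound 2 or compound 3.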